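Removing the amine methyl from compound 2

This account rests on a few compounds, and the source may have more. Where it says the series, first, only, none or still open, it means among the compounds named here.

Compound 1 `Cn1nc2c(=O)n(CC3(O)CCN(Cc4ccc(-c5ccco5)cc4Cl)CC3)cnc2c1-c1ccc(CNC=O)cc1` gives 1100 ng.h/mL in an ADME assay on the whole organism (Rattus norvegicus, strain Sprague-Dawley) for pharmacokinetics, read by LC-MS, with a stated time of 24 h, at a dose of 2 mg/kg by the intravenous route; on this read-out higher numbers stand for higher exposure at the dose given and lower numbers for lower exposure
Compound 2 `CNCc1ccc(-c2c3ncn(CC4(O)CCN(Cc5ccc(-c6ccco6)cc5Cl)CC4)c(=O)c3nn2C)cc1` gives 318 ng.h/mL in this assay

Compound 2 holds the lower of the two numbers. Compound 3 `Cn1nc2c(=O)n(CC3(O)CCN(Cc4ccc(-c5ccco5)cc4Cl)CC3)cnc2c1-c1ccc(CN)cc1` carries hydrogen in place of methyl on an amine nitrogen. Within the data shown here, the one measured step on that nitrogen is a 3.5-fold lower number from compound 1 to compound 2 (0.54 log units; beyond the scatter) and counts as modest, yet it puts methyl in place of formyl, which is a different exchange. In this assay no step beyond the scatter is therefore expected for compound 3. The estimated step is a 1.1-fold lower number from compound 2 to compound 3 (0.03 log units; within the scatter) and stays small. Compound 3 is expected at 300 ng.h/mL within an estimated range of 130 ng.h/mL to 700 ng.h/mL on this reasoning.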

Compound 3, area under the concentration-time curve: 335 ng.h/mL
Compound 3: middle estimate off by 1.1-fold (0.05 log units), on the low side; the measured number falls inside the stated range.
By their numbers in this assay, from the lowest: compounds 2 and 3 (each within the scatter of the next); then compound 1.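

In this assay, the methyl on this amine nitrogen turns out to matter little, with a 1.1-fold higher number from compound 2 to compound 3 (0.02 log units; within the scatter) as the whole step. The free amine stands apart from the formamide just as the methylamine does, with a 3.3-fold lower number from compound 1 to compound 3 (0.52 log units; beyond the scatter) on going from formyl to hydrogen, so at this nitrogen the formyl group alone separates the three compounds. On these data alone, whether an acetyl group or a longer chain on this nitrogen would stay with compound 1 or with compound 2 and compound 3 remains open. No measurement at hand explains the gap.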